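This account rests on a few compounds, and the source may have more. Where it says the series, first, only, none or still open, it means among the compounds named here.

Measured in an ADME assay on HepG2 2.2.15 cells (Homo sapiens) for cytotoxicity, read by MTT assay; on this read-out higher numbers stand for lower toxicity in this test and lower numbers for higher toxicity in this test:
- Compound 1 `C=C1CC[C@@H]2[C@](C)(COC(=O)c3ccccc3C(=O)O)[C@H](OC(=O)c3ccccc3C(=O)O)CC[C@@]2(C)[C@@H]1/C=C/C1=CCOC1=O`: > 1620000 nM, a limit of the assay
- Compound 2 `C=C1CC[C@@H]2[C@](C)(CO)[C@H](OC(C)=O)CC[C@@]2(C)[C@@H]1C/C=C1\C=COC1=O`: 872000 nM
- Compound 3 `C=C1CC[C@H]2[C@@](C)(CCC(=O)[C@@]2(C)C=O)[C@@H]1/C=C/C1=CCOC1=O`: 275000 nM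

Only two of these results are true numbers, and compound 3 holds the lower one, a gap to compound 2 that lies beyond the scatter. Compound 4 `C=C1CC[C@H]2[C@@](C)(CCC(=O)[C@@]2(C)C=O)[C@@H]1C/C=C1\C=COC1=O` has the same atoms as compound 3, joined differently, on a saturated ring carbon: a group of 8 heavy atoms (6 carbon, 2 oxygen; one five-membered non-aromatic ring with 1 hetero atom) in place of a group of 8 heavy atoms (6 carbon, 2 oxygen; one five-membered non-aromatic ring with 1 hetero atom), on a saturated ring carbon. Compound 2, at 872000 nM, carries the entering group too, but it also differs elsewhere, so it offers only a weak hint of a higher number. The expected change stays within the scatter, a 1.2-fold higher number from compound 3 to compound 4 (0.08 log units; within the scatter). For compound 4 the estimated value is 330000 nM, with an expected range of 130000 nM to 850000 nM.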

Compound 4, half-maximal cytotoxic concentration: 964000 nM
Beside the measured number, compound 4's estimate is 2.9-fold (0.47 log units) below it; the whole stated range lies below it.
By their numbers in this assay, from the lowest: compound 3; then compounds 2 and 4 (each within the scatter of the next). At a limit, above all of these: compound 1.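

In this assay, rejoining the same atoms of the group on this saturated ring carbon gives a 3.5-fold higher number from compound 3 to compound 4 (0.54 log units; beyond the scatter). Going by these compounds alone, the way this group is joined therefore matters in this test, even with no atom gained or lost, which the earlier compounds could not show because no two differed in one place only. Compound 1 still stands at a limit, not a number: the limit of > 1620000 nM in this assay, at which 1 of the 4 values shown sits.

From the compounds shown here alone, whether an amine or a longer chain on the five-membered ring would shift the number remains open. So does whether this rejoining has a similar effect on other cores.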